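Benzyl for Phenyl on the Amide Nitrogen

The source may hold more compounds than are shown below. What is called first, only, known or untested is meant among the compounds shown, and "the series" means these compounds.

The compounds share a core carrying an amide, and differ only in the group on its nitrogen. In a functional assay on MCF7 cells (Homo sapiens) for inhibition, read by MTT assay, with a stated time of 72 h (on this read-out higher numbers stand for weaker inhibition and lower numbers for stronger inhibition), compound 1 `O=C(Nc1ccccc1)C1CCN(C/C=C/c2ccccc2)CC1` gives 60200 nM, the highest number of the three measured, so the weakest inhibition seen. Compound 2 `N#Cc1ccc(NC(=O)C2CCN(C/C=C/c3ccccc3)CC2)cc1` gives 44500 nM, and compound 3 `O=C(Nc1nccs1)C1CCN(C/C=C/c2ccccc2)CC1` gives 28600 nM. The changes between them are small: a 1.4-fold lower number from compound 1 to compound 2 (0.13 log units; within the scatter), a 2.1-fold lower number from compound 1 to compound 3 (0.32 log units; beyond the scatter), and a 1.6-fold lower number from compound 2 to compound 3 (0.19 log units; within the scatter).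

Compound 4 `O=C(NCc1ccccc1)C1CCN(C/C=C/c2ccccc2)CC1` differs from compound 1 in one place: benzyl in place of phenyl on an amide-type nitrogen. Going by the values given here, none of the measured steps makes this exact change; all three swap one aromatic group for another directly on the nitrogen, and all stayed modest. Across these compounds the group on the amide nitrogen has moved the read-out little, so no step beyond the scatter is expected here. Compound 4 is estimated at 50000 nM, with a range of 18000 nM to 140000 nM, which means an expected step of a 1.2-fold lower number from compound 1 to compound 4 (0.08 log units; within the scatter).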

Compound 4, half-maximal inhibitory concentration: > 100000 nM
Compound 4 gave a limit, no number (the forecaster's own chance of this, stated with the estimate: 20%); middle value at least 2.0-fold (0.30 log units) from the limit.
By their numbers in this assay, from the lowest: compounds 3, 2 and 1 (each within the scatter of the next, the first and the last beyond it). At a limit, above all of these: compound 4.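

Compound 4 gave a limit of the assay, not a number: the limit of > 100000 nM in this assay, at which 1 of the 4 values shown sits. Benzyl in place of phenyl on the amide-type nitrogen gives an at least 1.6-fold higher number from compound 1 to compound 4 (0.22 log units; that floor lies within the scatter), so this floor alone does not separate the two compounds, whereas the other two comparisons, an at least 2.2-fold higher number from compound 2 to compound 4 (0.35 log units; beyond the scatter) and an at least 3.4-fold higher number from compound 3 to compound 4 (0.54 log units; beyond the scatter), do show a separation. The earlier compounds suggested that this position moves the read-out little, but benzyl, the only group shown whose aromatic ring is not attached directly to the nitrogen, is also the only one to end at a limit.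

As far as these compounds go, how far the true value of compound 4 lies beyond that limit stays open. Also open, from the compounds shown here alone, is what phenethyl, a longer chain, or a plain ethyl group would give on the same nitrogen.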